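The source may hold more compounds than are shown below. What is called first, only, known or untested is meant among the compounds shown, and "the series" means these compounds.

Compound 1 `COc1ccc(CNC(=O)c2cc(-c3cncc(C)c3)ncc2-c2cnccn2)nc1OC` in an assay on CHO cells for displacement of a labelled ligand from Orexin receptor type 2 (Homo sapiens), read by scintillation counting, with a stated time of 3 h; on this read-out higher numbers stand for weaker inhibition and lower numbers for stronger inhibition: 7.6 nM
Compound 2 `COc1ccc(CNC(=O)c2cc(-c3cncc(C)c3)ccc2-c2ccccc2)nc1OC` in this assay: 0.3 nM

Of the two measured compounds, compound 1 has the higher number. The gap between compound 1 and compound 2 is beyond the usual scatter of repeated runs. Compound 2 differs from compound 1 in more than one place, so the two values simply stand side by side and are not read here as a single step.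

Compound 3 `COc1ccc(CNC(=O)c2cc(-c3cncc(C)c3)ncc2-c2cnn(C)c2)nc1OC` has not yet been measured. It comes from compound 1 by one change: 1-methyl-1H-pyrazol-4-yl in place of pyrazin-2-yl on an aromatic carbon. Both groups carry the same count of heavy atoms and of hydrogen-bond acceptors, as counted in that description. Among the compounds with values here, no measured pair in this small set shows what such a swap does at that position, so there is no step from the data to lean on, and the expectation has to stay cautious. The estimated step of a 1.3-fold higher number from compound 1 to compound 3 (0.12 log units; within the scatter) amounts to no move beyond the scatter in either direction. Compound 3 is expected to give about 10 nM in this assay, with a likely range from 2 nM to 50 nM.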

Compound 3, inhibition constant: 4.1 nM
Estimate against measurement, compound 3: 2.4-fold (0.39 log units) above; the range from low to high includes it.
By their numbers in this assay, from the lowest: compound 2; then compounds 3 and 1 (each within the scatter of the next).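

Within the data shown here, replacing pyrazin-2-yl with 1-methyl-1H-pyrazol-4-yl on this aromatic carbon, ortho to a large group, gives a 1.9-fold lower number from compound 1 to compound 3 (0.27 log units; within the scatter) in this assay, the first step that can be read at this position. A six-membered aromatic ring with 2 hetero atoms has given way to a five-membered aromatic ring with 2 hetero atoms, with the counts of heavy atoms and hydrogen-bond acceptors unchanged, and this pair shows no change in the number that stands clear of the scatter. No measurement at hand explains why these two groups read alike here.

This single swap leaves open how the position would respond to a different kind of group, such as a carboxylic acid or a morpholine, since both groups compared here are aromatic rings of the same heavy-atom count. On these data alone, it is also open whether the same swap would read alike on another core, such as that of compound 2, which gives 0.3 nM but differs from compound 1 in more than one place.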